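Working notes: one methyl added to compound 2

A few compounds are considered here, and "the series" means these few. Any claim that something is new, unique, unknown or untested is made for them only; others in the source may bear on it.

In an ADME assay on J774 cells (Mus musculus) for cytotoxicity, read by resazurin assay, with a stated time of 72 h (a lower number here means that less compound is tolerated, a higher number that more compound is tolerated), compound 1 `C/C(=N\Nc1nc(C)c(C)s1)c1ccc(Cl)c(Cl)c1` gives 41800 nM as a measured number. Compound 2 `C/C(=N\Nc1nc(-c2ccccc2)cs1)c1ccc(Cl)c(Cl)c1` stands at > 50000 nM and this is a limit of the assay, not a number. Compound 3 `C/C(=N\Nc1nc(-c2ccccc2)c(C)s1)c1ccc(Cl)c(Cl)c1` is reached from compound 2 by one change, methyl in place of hydrogen on an aromatic carbon and the rest of the structure stays the same: methyl in place of hydrogen on an aromatic carbon. Going by the values given here, no measured pair isolates this change. Compound 1 also carries a methyl on that carbon and gives 41800 nM in this assay so the expectation leans on that single value. The expected step is an at least 1.1-fold lower number from compound 2 to compound 3 (0.07 log units; that floor lies within the scatter) and it is expected to be small, either within the scatter or slightly toward less compound tolerated. For compound 3 the estimated value is 42000 nM with an expected range from 20000 nM to 60000 nM in this read-out.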

Compound 3, half-maximal cytotoxic concentration: > 50000 nM
Compound 3 gave a limit, no number; the forecaster's own chance of this, stated with the estimate: 45%; middle value at least 1.1-fold (0.07 log units) from the limit.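

In this assay compound 3 stands at > 50000 nM, which is a limit of the assay and not a number. With the phenyl group in place, a methyl on the aromatic carbon next to the ring sulfur therefore still gives no measured number, and the step for this methyl cannot be read because compound 2 also carries a limit: the limit of > 50000 nM in this assay, at which 2 of the 3 values shown sit. Phenyl in place of methyl on an aromatic carbon gives an at least 1.1-fold higher number from compound 1 to compound 3 (0.07 log units; that floor lies within the scatter), so the printed floor of this step does not establish a change beyond the scatter.

Going by these compounds, how far compound 2 and compound 3 lie from each other remains open, since neither has a number. Also open, on these data alone, is whether an amine, a carboxylic acid or a longer chain on this same aromatic carbon would give a measured number in this assay.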